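Removing One Methoxy Group from the Aromatic Ring

The compounds below may be only part of what the source reports. "The series", "measured", "known", "first", "only" and "open" are said of these compounds alone.

Compound 1, `COc1cc(/C=C/C=C/C(=O)N2CCCCC2)cc(OC)c1OC`, stands higher of the two measured compounds in an assay for inhibition of Polyunsaturated fatty acid 5-lipoxygenase (Homo sapiens), read by spectrophotometry, tested at 20 uM (a higher number here means more inhibition at the concentration tested (going by the name of the read-out), a lower number less inhibition), where compound 1 gives 66.7%. Compound 2, `COc1cc(/C=C/C=C/C(=O)N2CCCCC2)cc(OC)c1O`, gives 32.7% in this assay, and the step of a number 34 percentage points lower from compound 1 to compound 2 (beyond the scatter), hydrogen in place of methyl on an oxygen on an aromatic ring, is large. Compound 3, `COc1ccc(/C=C/C=C/C(=O)N2CCCCC2)cc1OC`, differs from compound 1 by hydrogen in place of methoxy on an aromatic carbon. Going by the values given here, no measured step matches this change; only the step of a number 34 percentage points lower from compound 1 to compound 2 (beyond the scatter) shows that altering a methoxy group weakens inhibition. A drop of similar or somewhat smaller size is therefore expected, so a number 21.7 percentage points lower from compound 1 to compound 3 (beyond the scatter). Compound 3 is estimated at 45%, with a range from 25% to 65%.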

Compound 3, a percentage reported as inhibition, at one concentration (the size of the read-out at that concentration, not a potency): 51.9%
Beside the measured number, compound 3's estimate is 6.9 percentage points below it; low and high end bracket the measured number.
By their numbers in this assay, from the lowest: compound 2; then compound 3; then compound 1.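

Going by these compounds alone, replacing the methoxy group meta to a large group with hydrogen gives a number 14.8 percentage points lower from compound 1 to compound 3 (beyond the scatter) in this assay and shows that this methoxy group also counts for inhibition, not only the one altered in compound 2. Even without it, compound 3 gives 51.9% and keeps part of the inhibition seen with compound 1. No evidence on the cause of this step is available.

Going by these compounds, whether an amine or a fluorine atom on this carbon would bring inhibition closer to that of compound 1 remains open. The effect of a longer chain in place of the methoxy group is also unknown.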